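The source may report more compounds than this note shows. Statements on the series, on what has been measured and on what is new or still open speak of the compounds shown alone.

Measured so far, in a functional assay on cells (Erythrocyte, Homo sapiens); on this read-out higher numbers stand for weaker inhibition and lower numbers for stronger inhibition:
- compound 1 `COc1ccc2[nH]c(S(=O)(=O)Cc3ccc(OCc4nccc(OCC(F)(F)F)c4C)c(OC)c3)nc2c1`: 1760 nM
- compound 2 `COc1cc(CS(=O)(=O)c2nc3ccccc3[nH]2)ccc1OCc1ncc(C)c(OC)c1C`: 1820 nM
- compound 3 `COc1cc(CS(=O)(=O)c2nc3ccccc3[nH]2)ccc1OCc1nccc(OC)c1OC`: 212 nM

Compound 1 stands second highest of these three numbers; compound 2 sits within the scatter of it, while compound 3 lies well below both. Within the data shown here, the only measured step, an 8.6-fold lower number from compound 2 to compound 3 (0.93 log units; beyond the scatter), concerns a change at a different place and so says nothing about the change now in question. Compound 4 `COc1cc(CS(=O)(=O)c2nc3cc(OC(F)F)ccc3[nH]2)ccc1OCc1nccc(OCC(F)(F)F)c1C` differs from compound 1 by difluoromethyl in place of methyl on an oxygen on an aromatic ring. Among the measured compounds shown here, no measured pair shows what this exchange does, so the expectation for compound 4 rests on compound 1 alone, with no step beyond the scatter expected: a 1.0-fold lower number from compound 1 to compound 4 (0.02 log units; within the scatter). Compound 4 is therefore estimated at 1700 nM, in a range from 600 nM to 4800 nM.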

Compound 4, half-maximal inhibitory concentration: 1880 nM
For compound 4 the middle estimate is 1.1-fold (0.04 log units) below the measured one; the measured number falls inside the stated range.
By their numbers in this assay, from the lowest: compound 3; then compounds 1, 2 and 4 (each within the scatter of the next).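

In this assay, difluoromethyl in place of methyl on an oxygen on an aromatic ring gives a 1.1-fold higher number from compound 1 to compound 4 (0.03 log units; within the scatter) and so stays within the scatter. Among these compounds, the earlier compounds showed a step only at a different place, so this is the first reading of the methoxy to difluoromethoxy change, and the number does not respond measurably to it. No evidence is available to explain this result.

Going by these compounds, whether a longer chain such as propyl on this oxygen, or an amine in place of the oxygen, would shift the number remains open. Also open, on these data alone, is whether the same exchange would behave alike alongside the 3,4-dimethoxypyridin-2-yl group of compound 3.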